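A few compounds are considered here, and "the series" means these few. Any claim that something is new, unique, unknown or untested is made for them only; others in the source may bear on it.

Series notes. Compound 1 `OC1CCN(c2ncnc3[nH]cc(-c4cccc(Cl)c4)c23)CC1` gives 127 nM in an assay for inhibition of serine/threonine-protein kinase 3 (Homo sapiens), read by luminescence and ADP-Glo, in the presence of a further agent that is not named here; a higher number here means a weaker inhibitor, a lower number a stronger inhibitor; compound 2 `Clc1cccc(-c2c[nH]c3ncnc(N4CCCCC4)c23)c1` gives 167 nM, the higher of the two numbers. The step of a 1.3-fold higher number from compound 1 to compound 2 (0.12 log units; within the scatter) shows that removing the hydroxy changes little. Compound 3 `CC1(N)CCN(c2ncnc3[nH]cc(-c4cccc(Cl)c4)c23)CC1` differs from compound 2 by 4-amino-4-methylpiperidin-1-yl in place of piperidin-1-yl on an aromatic carbon. Among the measured compounds shown here, no measured step covers an amine at this saturated ring carbon; the hydroxy step is the only guide and lay within the scatter, so the change is expected to be a 1.3-fold lower number from compound 2 to compound 3 (0.11 log units; within the scatter), with no shift beyond the scatter. Compound 3 is estimated at 130 nM, within 40 nM to 400 nM.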

Compound 3, half-maximal inhibitory concentration: 278 nM
For compound 3 the middle estimate is 2.1-fold (0.33 log units) below the measured one; the measured number falls inside the stated range.
By their numbers in this assay, from the lowest: compounds 1, 2 and 3 (each within the scatter of the next, the first and the last beyond it).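

In this assay this aromatic carbon accepts the larger 4-amino-4-methylpiperidin-1-yl group with only a small shift: the step is a 1.7-fold higher number from compound 2 to compound 3 (0.22 log units; within the scatter) against the unsubstituted piperidin-1-yl. Against the hydroxy analogue the step is a 2.2-fold higher number from compound 1 to compound 3 (0.34 log units; beyond the scatter) and is the first in the series to pass the scatter, though it remains modest. Nothing available here accounts for either step.

Going by these compounds, the amino and methyl groups enter together, so their separate contributions remain open. A 4-aminopiperidin-1-yl without the methyl, or a 4-methylpiperidin-1-yl without the amine, would separate them.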